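This account rests on a few compounds, and the source may have more. Where it says the series, first, only, none or still open, it means among the compounds named here.

Compound 1 `COc1ccc(N(C)c2nc(C)nc3ccccc23)cc1C(=O)OCCC[Se]C#N` is the starting point. In a functional assay on HCT-116 cells (Homo sapiens) for inhibition, read by MTT assay, with a stated time of 48 h (on this read-out lower numbers stand for stronger inhibition and higher numbers for weaker inhibition), compound 1 gives 720 nM, the second highest of the three measured numbers. Nearest stands compound 3 `COc1ccc(N(C)c2nc(C)nc3ccccc23)cc1OCCC[Se]C#N`, which gives 852 nM; the change is a 1.2-fold higher number from compound 1 to compound 3 (0.07 log units; within the scatter). Furthest stands compound 2 `COc1ccc(N(C)c2nc(C)nc3ccccc23)cc1C[Se]C#N`, which gives 113 nM after a 6.4-fold lower number from compound 1 to compound 2 (0.80 log units; beyond the scatter).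

Compound 4 `COc1ccc(N(C)c2nc(C)nc3ccccc23)cc1C(=O)OCCCCCC[Se]C#N` has not yet been measured. It differs from compound 1 in one place: a group of 6 heavy atoms (4 carbon, 1 nitrogen, 1 selenium; no ring) in place of a group of 3 heavy atoms (1 carbon, 1 nitrogen, 1 selenium; no ring), on a saturated chain carbon, three bonds along the chain from an oxygen next to a carbonyl group. The selenium-bearing chain is therefore longer, not shorter.

The two measured steps that bear on this both remodel the same chain. Going to the shortest chain, in compound 2, gave the only step beyond the scatter, and it lowered the number; going to the chain of compound 3 stayed within the scatter. For the measured compounds named here, no measured compound carries a chain longer than compound 1, so a further lengthening has no direct precedent. A small rise in the number, or no change beyond the scatter, is the expectation, with wide uncertainty.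

For compound 4 the expected value is 1100 nM, within 450 nM to 2700 nM. That expected step is a 1.5-fold higher number from compound 1 to compound 4 (0.18 log units; within the scatter).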

Compound 4, half-maximal inhibitory concentration: 1990 nM
The estimate for compound 4 lay 1.8-fold (0.26 log units) below the measured number; the measured number falls inside the stated range.
By their numbers in this assay, from the lowest: compound 2; then compounds 1 and 3 (each within the scatter of the next); then compound 4.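

In this assay, the group of 6 heavy atoms in place of the group of 3 heavy atoms brings a 2.8-fold higher number from compound 1 to compound 4 (0.44 log units; beyond the scatter) and so weakens inhibition. For the compounds shown here, this is the first sign that this position responds to added length on the side beyond compound 1, since no earlier compound carries a longer chain. With only these two chain lengths on this linkage, the step gives a direction for this one pair and not a trend, and nothing measured here explains why the number rises.

The compounds shown leave open whether a still longer chain would raise the number further, and how chains of intermediate length would behave. They also leave open whether a chain holding an amine, or a sulfur atom in place of the selenium, would give a similar result.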